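The compounds below may be only part of what the source reports. "The series", "measured", "known", "first", "only" and "open" are said of these compounds alone.

Working notes, this series. In a functional assay on SW-620 cells (Homo sapiens) for inhibition, read by sulforhodamine B assay, with a stated time of 48 h (a lower number here means a stronger inhibitor of growth, a higher number a weaker inhibitor of growth), compound 1 `COc1cc(-c2nn(-c3cccc(NC(=O)c4ccc(Cl)c(C(F)(F)F)c4)c3)cc2-c2ccncc2)ccc1Cl` gives 4750 nM, compound 2 `COc1cc(-c2nn(-c3cccc(NC(=O)c4cccc(C(F)(F)F)c4)c3)cc2-c2ccncc2)ccc1Cl` gives 2310 nM, and compound 3 `O=C(Nc1cccc(-n2cc(-c3ccncc3)c(-c3ccc(Cl)c(O)c3)n2)c1)Nc1cc(C(F)(F)F)cc(C(F)(F)F)c1` gives 1300 nM. Among the compounds with values here, compound 2 stands second highest of the three numbers: its nearest neighbour is compound 3, within the scatter, and its furthest is compound 1, with the one measured single-point step being a 2.1-fold lower number from compound 1 to compound 2 (0.31 log units; beyond the scatter). Compound 4 `COc1cc(-c2nn(-c3cccc(NC(=O)Nc4cccc(C(F)(F)F)c4)c3)cc2-c2ccncc2)ccc1Cl` differs from compound 2 in one place: (3-(trifluoromethyl)phenyl)amino in place of 3-(trifluoromethyl)phenyl on a carbonyl carbon. Within the data shown here, no measured step covers this change. Compound 3 also carries a carbonyl flanked by two amide-type nitrogens, but differs from compound 2 elsewhere as well, so only its value can be set beside that of compound 2, and the two lie within the scatter. For compound 4 the expected step is therefore a 1.3-fold lower number from compound 2 to compound 4 (0.11 log units; within the scatter), not beyond the scatter. Compound 4 is estimated at 1800 nM, within 700 nM to 4500 nM.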

Compound 4, concentration for 50% growth inhibition: 1230 nM
The estimate for compound 4 lay 1.5-fold (0.17 log units) above the measured number, within the range that was stated.
By their numbers in this assay, from the lowest: compounds 4, 3 and 2 (each within the scatter of the next); then compound 1.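

At this carbonyl carbon, (3-(trifluoromethyl)phenyl)amino in place of 3-(trifluoromethyl)phenyl gives a 1.9-fold lower number from compound 2 to compound 4 (0.27 log units; within the scatter) in this assay, so the added amide-type nitrogen and its hydrogen-bond donor leave the number unchanged within the scatter. Against the chloro-bearing group, the same entering group gives a 3.9-fold lower number from compound 1 to compound 4 (0.59 log units; beyond the scatter), a step that combines the new nitrogen with the absence of chloro. No data at hand bear on what lies behind these numbers.

Open, going by these compounds, is whether an oxygen or a methylene in place of the new nitrogen would give a comparable number. Also open, on these data alone, is how an amine or a carboxylic acid in place of trifluoromethyl would read in this assay.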